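This account rests on a few compounds, and the source may have more. Where it says the series, first, only, none or still open, it means among the compounds named here.

Measured so far in an assay on isolated protein for inhibition of cytochrome c oxidase subunit 2 (Homo sapiens), read by ELISA, with a stated time of 2 min, tested at 10 uM; a higher number here means more inhibition at the concentration tested (going by the name of the read-out), a lower number less inhibition:
compound 1 `O=C1C=C(Nc2ccc(F)cc2)CCC1` gives 55.6%
compound 2 `CSc1ccc(NC2=CC(=O)CCC2)cc1` gives 27.8%
compound 3 `O=C1C=C(Nc2ccc(F)cc2)CC1` gives 22.3%

Compound 3 has the lowest number of the three; its gap to compound 2 lies within the scatter, its gap to compound 1 beyond it. Compound 4 `O=C1C=C(Nc2ccc(Cl)cc2)CC1` is not yet measured; it differs from compound 3 by chloro in place of fluoro on an aromatic carbon. For the measured compounds named here, the only measured step, a number 27.8 percentage points lower from compound 1 to compound 2 (beyond the scatter), concerns a different replacement on a different core and does not bear directly on this change; no measured pair exchanges one halogen for another. Lacking a relevant step, the expected step of a number 0.7 percentage points higher from compound 3 to compound 4 (within the scatter) is no change beyond the scatter. Compound 4 is therefore estimated at 23%, with a range from 5% to 42%.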

Compound 4, a percentage reported as inhibition, at one concentration (the size of the read-out at that concentration, not a potency): 33.5%
The estimate for compound 4 lay 10.5 percentage points below the measured number, within the range that was stated.
By their numbers in this assay, from the lowest: compounds 3, 2 and 4 (each within the scatter of the next, the first and the last beyond it); then compound 1.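

In this assay, for the compounds shown here, the halogen on the aromatic carbon is not interchangeable on this core: a number 11.2 percentage points higher from compound 3 to compound 4 (beyond the scatter) in the first halogen-for-halogen pair of the series. Going by these compounds alone, the earlier step at this position exchanged fluoro for methylsulfanyl on the core of compound 1, so this is the first change at this position on the core of compound 3. Nothing independent of this read-out accounts for the step.

On these data alone, whether chloro in place of fluoro moves the number the same way on the core of compound 1 remains open. So does the reading of bromo, methoxy or an amine at this position.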